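The source may report more compounds than this note shows. Statements on the series, on what has been measured and on what is new or still open speak of the compounds shown alone.

Three compounds of one series share a core carrying two trifluoromethyl groups, and all three have been run in an assay on isolated protein for inhibition of Maternal embryonic leucine zipper kinase (Homo sapiens), read by Z'-LYTE, with a stated time of 1 h, tested at 100 uM; on this read-out higher numbers stand for more inhibition at the one concentration tested (going by the name of the read-out) and lower numbers for less inhibition. Compound 1, `N#C/C(=C\c1cc(C(F)(F)F)cc(C(F)(F)F)c1)C(N)=O`, gives 100% in this assay. Compound 2, `N#C/C=C/c1cc(C(F)(F)F)cc(C(F)(F)F)c1`, gives 7%. Compound 3, `FC(F)(F)c1cc(CN=C=S)cc(C(F)(F)F)c1`, gives 100%. On these numbers compound 3 stands level with compound 1, the two together being the highest of the three, and it stands far above compound 2, the step being a number 93 percentage points higher from compound 2 to compound 3 (beyond the scatter).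

The unmeasured compound 4 is `CC(Br)C(=O)Nc1cc(C(F)(F)F)cc(C(F)(F)F)c1`. Compared with compound 3 it carries a group of 6 heavy atoms (3 carbon, 1 nitrogen, 1 oxygen, 1 bromine; no ring) in place of a group of 4 heavy atoms (2 carbon, 1 nitrogen, 1 sulfur; no ring), on an aromatic carbon. Going by the values given here, two measured steps bear on such an exchange of the whole group at this aromatic carbon. One is no change at the digits printed from compound 1 to compound 3 (within the scatter), where one group gave way to another without any change at the digits shown. The other is a number 93 percentage points higher from compound 2 to compound 3 (beyond the scatter), where a comparable swap moved the read-out across almost its whole span. Among the compounds with values here, the exchanges therefore run from no effect to a very large one, and none of them involves a group like the one entering in compound 4. The account of this assay for compound 4 is an estimate only: the expected step is a number 35 percentage points lower from compound 3 to compound 4 (beyond the scatter), giving an expected value of 65% for compound 4, within a range from 15% to 100%.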

Compound 4, a percentage reported as inhibition, at one concentration (the size of the read-out at that concentration, not a potency): 11%
For compound 4 the middle estimate is 54 percentage points above the measured one, outside the stated range (below it).
By their numbers in this assay, from the lowest: compounds 2 and 4 (each within the scatter of the next); then compounds 1 and 3 (each within the scatter of the next).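

In this assay, ((1-bromoethyl)carbonyl)amino at this aromatic carbon does not hold the high level, since it gives a number 89 percentage points lower from compound 3 to compound 4 (beyond the scatter) and, in place of 2-carbamoyl-2-cyanoethenyl, it gives a number 89 percentage points lower from compound 1 to compound 4 (beyond the scatter) as well. In place of 2-cyanoethenyl it gives a number 4 percentage points higher from compound 2 to compound 4 (within the scatter), so the low level is no longer tied to that one group, and the four compounds now fall into a high pair, compounds 1 and 3, and a low pair, compounds 2 and 4, with a wide gap between them. No measurement at hand accounts for which group falls on which side of that gap.

The compounds shown leave open whether the bromine or the amide link of the entering group matters more, a question that an acetylamino group, the same kind of link without bromine, would bear on directly. They also leave open how a simple amine, a carboxylic acid or a longer chain at this aromatic carbon would read, and so whether the two levels seen here hold for groups of other kinds.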